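This account rests on a few compounds, and the source may have more. Where it says the series, first, only, none or still open, it means among the compounds named here.

Measured so far in a physicochemical assay for lipophilicity (on this read-out lower numbers stand for lower lipophilicity and higher numbers for higher lipophilicity), for the series:
compound 1 `CC#CCn1c(N2CCC[C@@H](N)C2)cc(=O)n(Cc2cc(OC)c(OC)c(Br)c2Br)c1=O` gives 3.21
compound 2 `CC#CCn1c(N2CCC[C@@H](N)C2)cc(=O)n(Cc2cc(C)cc(C)c2)c1=O` gives 2.78
compound 3 `Cc1cc(C)cc(Cn2c(=O)cc(N3CCC[C@@H](N)C3)n(Cc3cc(F)ccc3C#N)c2=O)c1` gives 3.89

Compound 3 carries the highest number of the three. The gaps down to compound 1 and compound 2 both lie beyond the scatter, with compound 1 the nearer. Next comes compound 4 `CCCCCCCCCCn1c(=O)cc(N2CCC[C@@H](N)C2)n(Cc2cc(F)ccc2C#N)c1=O`, still unmeasured. The change nonyl in place of 3,5-dimethylphenyl on a saturated chain carbon bound to an aromatic nitrogen puts nonyl in place of 3,5-dimethylphenyl on a saturated chain carbon bound to an aromatic nitrogen.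

Among the measured compounds shown here, one measured step bears on this, and only indirectly: a number 1.11 log units higher from compound 2 to compound 3 (beyond the scatter), with 2-cyano-5-fluorophenyl in place of prop-1-yn-1-yl at the same kind of place. That large step shows that an exchange on such a carbon can move this assay well beyond the scatter. For the measured compounds named here, no measured step removes 3,5-dimethylphenyl or brings in nonyl, so the upward direction expected here is a judgement from the structural change alone. A rise somewhat smaller than that measured step is expected, and the estimated move is a number 0.71 log units higher from compound 3 to compound 4 (beyond the scatter) on this scale. For compound 4 the expected value is 4.6 with an estimated range from 4 to 5.3 as the working figure.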

Compound 4, partition coefficient: 4.93
The estimate for compound 4 lay 0.33 log units below the measured number, and the stated range covers the measured number.
By their numbers in this assay, from the lowest: compound 2; then compound 1; then compound 3; then compound 4.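

In this assay, the exchange of 3,5-dimethylphenyl for nonyl on a saturated chain carbon bound to an aromatic nitrogen gives a number 1.04 log units higher from compound 3 to compound 4 (beyond the scatter), which shows that a large upward move in this series does not depend on keeping that aromatic ring. The 2-cyano-5-fluorophenyl group stays in place across this step, and the exchanged group is not the one that changed in the earlier step, a number 1.11 log units higher from compound 2 to compound 3 (beyond the scatter), so two different substituents on the shared core have now each produced a large rise in this assay. Neither the leaving nor the entering group has hydrogen-bond donors or acceptors, and nothing available explains the rise.

This single exchange removes the ring and alters the carbon count together, so the compounds shown cannot separate those two changes; a shorter chain such as butyl, or a benzyl group in place of the decyl group on a comparable core, would bear on that. From the compounds shown here alone, how the read-out responds to a terminal amine or a carboxylic acid on the decyl chain also remains open.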